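The source may report more compounds than this note shows. Statements on the series, on what has been measured and on what is new or still open speak of the compounds shown alone.

Compound 1 `O=S(=O)(c1ccc(F)cc1)N(Cc1cccc(F)c1F)Cc1cn(S(=O)(=O)c2ccc(F)cc2)c2ccccc12`: -20%
Compound 2 `Cc1ccc(S(=O)(=O)N(Cc2cccc(F)c2F)Cc2cn(S(=O)(=O)c3ccc(F)cc3)c3ccccc23)cc1`: -35%
Compound 3 `O=C(N(Cc1cccc(F)c1F)Cc1cn(S(=O)(=O)c2ccc(F)cc2)c2ccccc12)C(F)(F)F`: -52.3%

All three were measured in a functional assay on 3T3-L1 cells (Mus musculus) for inhibition, with a stated time of 20 min, tested at 20 uM; on this read-out lower numbers stand for less inhibition and higher numbers for more inhibition at the one concentration tested (going by the name of the read-out). Compound 3 stands lowest of the three: the step of a number 32.3 percentage points lower from compound 1 to compound 3 (beyond the scatter) and the step of a number 17.3 percentage points lower from compound 2 to compound 3 (beyond the scatter) both lie beyond the scatter, so compound 3 shows the least inhibition seen so far. Compound 4 `CC(=O)N(Cc1cccc(F)c1F)Cc1cn(S(=O)(=O)c2ccc(F)cc2)c2ccccc12` is the unmeasured compound; it differs from compound 3 in one place: methyl in place of trifluoromethyl on a carbonyl carbon. None of the measured steps touches the trifluoromethyl group, so nothing shown bears directly on this change; the two steps that reached compound 3 replaced the whole group on the nitrogen, whereas here the carbonyl stays. A step in this assay within the usual scatter, in either direction, is therefore expected. Compound 4 is estimated at -45%, between -68% and -22%, an expected step of a number 7.3 percentage points higher from compound 3 to compound 4 (within the scatter).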

Compound 4, a percentage reported as inhibition, at one concentration (the size of the read-out at that concentration, not a potency): 25.8%
For compound 4 the middle estimate is 70.8 percentage points below the measured one; measured number outside the range, above it.
By their numbers in this assay, from the lowest: compound 3; then compound 2; then compound 1; then compound 4.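

On the carbonyl carbon, a single small group turns out to decide the result: in this assay methyl in place of trifluoromethyl gives a number 78.1 percentage points higher from compound 3 to compound 4 (beyond the scatter). Keeping a carbonyl on the amine nitrogen is therefore not enough by itself, yet acetyl also stands well clear of (4-methylphenyl)sulfonyl, with a number 60.8 percentage points higher from compound 2 to compound 4 (beyond the scatter), and of (4-fluorophenyl)sulfonyl, with a number 45.8 percentage points higher from compound 1 to compound 4 (beyond the scatter). Among these four, only compound 4 has a positive number. No measurement here explains this swing. On these data alone, how ethyl or difluoromethyl on the same carbonyl carbon would read remains open.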